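This account rests on a few compounds, and the source may have more. Where it says the series, first, only, none or still open, it means among the compounds named here.

Measured in a functional assay on TK-10 cells (Homo sapiens) for cytotoxicity, read by sulforhodamine B assay, with a stated time of 48 h; a lower number here means a stronger inhibitor of growth, a higher number a weaker inhibitor of growth:
compound 1, `ClCc1cccc(Cn2cnc3c(Cl)ncnc32)c1`, gives 4570 nM
compound 2, `ClCc1ccc(Cn2cnc3nc(Cl)nc(Cl)c32)cc1`, gives 120 nM
compound 3, `ClCc1cccc(Cn2cnc3c(Cl)nc(Cl)nc32)c1`, gives 1730 nM

Compound 2 gives the lowest of the three numbers; the difference between its core and the core of compound 3 is not broken down here. Compound 3 and compound 1 differ by hydrogen in place of chloro on an aromatic carbon, and this change gave a 2.6-fold higher number from compound 3 to compound 1 (0.42 log units; beyond the scatter). Compound 4, `ClCc1ccc(Cn2cnc3ncnc(Cl)c32)cc1`, has not yet been measured; it differs from compound 2 by hydrogen in place of chloro on an aromatic carbon, at a place described in exactly the same words, so it is the same change. Compound 4 is expected to show a similar step, a 2.8-fold higher number from compound 2 to compound 4 (0.44 log units; beyond the scatter), because the same change gave a 2.6-fold higher number from compound 3 to compound 1 (0.42 log units; beyond the scatter). The estimate for compound 4 in this assay is therefore 330 nM, most likely falling between 140 nM and 900 nM.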

Compound 4, concentration for 50% growth inhibition: 1470 nM
The estimate for compound 4 lay 4.5-fold (0.65 log units) below the measured number; the measured number lies above the stated range.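

In this assay, putting hydrogen in place of chloro on the aromatic carbon between two ring nitrogen atoms gave a 12-fold higher number from compound 2 to compound 4 (1.09 log units; beyond the scatter). The direction carried over from one core to the other, but the size did not: the same change on two cores in this assay, a 2.6-fold higher number (0.42 log units; beyond the scatter) from compound 3 to compound 1 and a 12-fold higher number (1.09 log units; beyond the scatter) from compound 2 to compound 4, 4.6-fold (0.67 log units) apart, beyond the scatter of two such steps. So these two pairs suggest that this change raises the number, but one pair cannot set the size for another, and the pairs differ in more than one place, so they cannot show what sets the size.

The compounds shown leave open how an amine or a methoxy group would behave at that same carbon. They also leave open whether the direction would hold on further cores.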